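Swapping an aminophenyl for a difluorophenyl

The source may report more compounds than this note shows. Statements on the series, on what has been measured and on what is new or still open speak of the compounds shown alone.

Of the compounds shown here, two with a shared core have been tested in a functional assay on NCI-H522 cells (Homo sapiens) for inhibition, read by sulforhodamine B assay, with a stated time of 48 h; a lower number here means a stronger inhibitor of growth, a higher number a weaker inhibitor of growth. Compound 1 `COc1cc(-c2cc(/C=C/C(=O)c3ccc(N)cc3)[nH]n2)cc(OC)c1OC` gives 3990 nM, and compound 2 `COc1ccc(-c2cc(/C=C/C(=O)c3ccc(N)cc3)[nH]n2)cc1OC` gives 3220 nM. The step of a 1.2-fold lower number from compound 1 to compound 2 (0.09 log units; within the scatter) changes nothing that can be read as real. Compound 1 has the higher of the two numbers, yet its gap to compound 2 is within the scatter, so no order between them can be claimed.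

Compound 3 `COc1cc(-c2cc(/C=C/C(=O)c3ccc(F)c(F)c3)[nH]n2)cc(OC)c1OC` differs from compound 1 in one place: 3,4-difluorophenyl in place of 4-aminophenyl on a carbonyl carbon. Among the compounds with values here, the single measured step concerns a methoxy on the other aromatic ring, so no measured step bears on the ring attached to the carbonyl, and the data give no direction for this change. The expectation for compound 3 is therefore a number near that of compound 1, with a wide range: 4000 nM, between 1300 nM and 12000 nM. This estimate means a step of a 1.0-fold higher number from compound 1 to compound 3 (0.00 log units; within the scatter) that is expected to fall within the scatter.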

Compound 3, concentration for total growth inhibition: 4480 nM
Beside the measured number, compound 3's estimate is 1.1-fold (0.05 log units) below it; low and high end bracket the measured number.
By their numbers in this assay, from the lowest: compounds 2, 1 and 3 (each within the scatter of the next).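

Within the data shown here, the step of a 1.1-fold higher number from compound 1 to compound 3 (0.05 log units; within the scatter) in this assay is the first measured change to the group on the carbonyl carbon, and it gives no readable difference. On the core of compound 1, 4-aminophenyl, which counts a hydrogen-bond donor and a hydrogen-bond acceptor, can therefore be exchanged for 3,4-difluorophenyl, which counts neither, with the number staying within the scatter. No measured evidence on these compounds explains this result, and a single exchange that removes the amine and adds both fluorines cannot show what each part contributes.

The compounds shown leave open how a plain phenyl ring, a phenyl ring with a single fluorine or one carrying a carboxylic acid would read on this carbonyl carbon. They also leave open whether 3,4-difluorophenyl would give a similar reading on the core of compound 2.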